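A few compounds are considered here, and "the series" means these few. Any claim that something is new, unique, unknown or untested is made for them only; others in the source may bear on it.

In a physicochemical assay for solubility, in phosphate buffer, at pH 6.5 (on this read-out lower numbers stand for lower solubility and higher numbers for higher solubility), compound 2 `CCOc1cc(CN2CCC(NC(=O)c3cncc(C)c3)CC2)cc(OCC)c1-c1ccc(F)cc1` gives 94 ug/mL, which lies within the scatter of the two related compounds: compound 1 `CCOc1cc(CN2CCC(NC(=O)c3ccc(Cl)nc3)CC2)cc(OCC)c1-c1ccc(F)cc1` gives 76 ug/mL and compound 3 `CCOc1cc(CN2CCC(NC(=O)c3cncc(C)c3)CC2)ccc1-c1ccc(F)cc1` gives 101 ug/mL. Compound 4 `CCOc1cc(CN2CCC(NC(=O)c3cncc(C)c3)CC2)cc(OCC)c1F` differs from compound 2 by one change: fluoro in place of 4-fluorophenyl on an aromatic carbon. Two measured steps offer some guidance. Placing 5-methylpyridin-3-yl where 6-chloropyridin-3-yl stood gave a 1.2-fold higher number from compound 1 to compound 2 (0.09 log units; within the scatter), and hydrogen in place of ethoxy gave a 1.1-fold higher number from compound 2 to compound 3 (0.03 log units; within the scatter). Neither step touches the 4-fluorophenyl, so both guide this change only loosely, and no step beyond the scatter is expected in this assay. The expected step is a 1.2-fold higher number from compound 2 to compound 4 (0.09 log units; within the scatter). The estimated value for compound 4 is 115 ug/mL, with an expected range from 50 ug/mL to 260 ug/mL.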

Compound 4, solubility: 443 ug/mL
Beside the measured number, compound 4's estimate is 3.9-fold (0.59 log units) below it, and the stated range ends below it.
By their numbers in this assay, from the lowest: compounds 1, 2 and 3 (each within the scatter of the next); then compound 4.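

In this assay, fluoro in place of 4-fluorophenyl gives a 4.7-fold higher number from compound 2 to compound 4 (0.67 log units; beyond the scatter), the first step shown that lies beyond the scatter. The earlier steps, one at the amide's pyridine group and one at an ethoxy, stayed within the scatter, so this position, ortho to two ethoxy groups, is the only place shown where a change clearly moves the number. Nothing measured here accounts for the rise. On these data alone, whether it depends on removing the ring or on the fluoro itself remains open, and a nitrile or a methoxy at this position would help separate the two. Also open, as far as these compounds go, is whether the same change would give a similar step with the 6-chloropyridin-3-yl in place of 5-methylpyridin-3-yl.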